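The source may report more compounds than this note shows. Statements on the series, on what has been measured and on what is new or still open speak of the compounds shown alone.

Compound 1 `COc1ccc(/C=C/C(=O)c2ccc(NC(=O)CBr)cc2)cc1` gave 46% in a functional assay on the whole organism (strain albino) for inhibition, with Rattus norvegicus as the target, read by paw edema, with stated times of 30 min and 3 h, at a dose of 100 mg/kg by the oral route; a higher number here means more inhibition at the dose given (going by the name of the read-out), a lower number less inhibition. Compound 2 `COc1ccc(/C=C/C(=O)c2ccc(NC(=O)CO[N+](=O)[O-])cc2)cc1` gave 53% in this assay. Compound 3 `C/C(=N/O)c1ccc(OCC(=O)Nc2ccc(C(=O)/C=C/c3ccc(Cl)cc3)cc2)cc1` gave 66% in this assay.

Compound 3 stands highest of the three; compound 2 is nearest, lower beyond the scatter, and compound 1 is furthest, also lower beyond the scatter. Compound 4 `COc1ccc(/C=C/C(=O)c2ccc(NC(=O)COc3ccc(/C(C)=N\O)cc3)cc2)cc1` differs from compound 3 by methoxy in place of chloro on an aromatic carbon. For the measured compounds named here, the only measured step, a number 7 percentage points higher from compound 1 to compound 2 (within the scatter), exchanges groups on a saturated chain carbon bound to a carbonyl carbon, not on an aromatic ring, so it does not bear on this change; no measured pair exchanges chloro for methoxy. With nothing to point either way, compound 4 is expected to sit near compound 3, with a step of a number 6 percentage points lower from compound 3 to compound 4 (within the scatter) that is expected to stay within the scatter. Compound 4 is estimated at 60%, expected between 46% and 72% in this assay.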

Compound 4, a percentage reported as inhibition, in the whole organism at one dose (the size of the read-out at that dose, not a potency): 46%
For compound 4 the middle estimate is 14 percentage points above the measured one; low and high end bracket the measured number.
By their numbers in this assay, from the lowest: compounds 1, 4 and 2 (each within the scatter of the next); then compound 3.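

In this assay, for the compounds shown here, the change from 4-chlorophenyl to 4-methoxyphenyl gives a number 20 percentage points lower from compound 3 to compound 4 (beyond the scatter) and is the first measured exchange on an aromatic carbon, showing that the number responds to the group at this place. With 4-methoxyphenyl kept, the exchanges on the chain read a number 7 percentage points lower from compound 2 to compound 4 (within the scatter) and no change at the digits printed from compound 1 to compound 4 (within the scatter) so the large group of compound 4 shows no gain over nitrooxy or bromo. Nothing available explains the drop from chloro to methoxy. Going by these compounds, whether chloro holds its higher number with bromo or nitrooxy on the chain stays open. So does how fluoro, hydroxy or an amine would read at this aromatic carbon.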